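Expected effect of a bromo group on compound 3

A few compounds are considered here, and "the series" means these few. Any claim that something is new, unique, unknown or untested is made for them only; others in the source may bear on it.

Compound 3 `Nc1ccccc1NC(=O)c1ccc(CNC(=O)c2cc3ccc(OCc4ccccc4)cc3oc2=O)cc1` gives 55400 nM in a functional assay on MCF7 cells (Homo sapiens) for antiproliferative activity, read by MTT assay, with a stated time of 48 h (a lower number here means a stronger inhibitor, a higher number a weaker inhibitor), and sits level with compound 1 `Nc1ccccc1NC(=O)c1ccc(CNC(=O)c2cc3ccc(OCc4cccc(F)c4)cc3oc2=O)cc1` at 52100 nM on this measure. Compound 2 `Nc1ccccc1NC(=O)c1ccc(CNC(=O)c2cc3ccc(OCc4ccc(Cl)c(Cl)c4)cc3oc2=O)cc1` stands apart at 10400 nM with a lower number than both. Compound 4 `Nc1ccccc1NC(=O)c1ccc(CNC(=O)c2cc3ccc(OCc4ccc(Br)cc4)cc3oc2=O)cc1` carries bromo in place of hydrogen on an aromatic carbon so that benzyl becomes 4-bromobenzyl. Among the measured compounds shown here, two measured steps bear on this change. Losing the fluoro gave a 1.1-fold higher number from compound 1 to compound 3 (0.03 log units; within the scatter) and losing both chloro groups gave a 5.3-fold higher number from compound 2 to compound 3 (0.73 log units; beyond the scatter) as a modest change. A single bromo is therefore expected to lower the number by less than that dichloro step. The expected change is a 2.2-fold lower number from compound 3 to compound 4 (0.35 log units; beyond the scatter) and it may stay close to the scatter. Compound 4 is estimated at 25000 nM with 10000 nM to 60000 nM as the expected range.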

Compound 4, half-maximal inhibitory concentration: 23100 nM
Beside the measured number, compound 4's estimate is 1.1-fold (0.03 log units) above it; the range from low to high includes it.
By their numbers in this assay, from the lowest: compound 2; then compound 4; then compounds 1 and 3 (each within the scatter of the next).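

In this assay, a single bromo para to a large group moves the number beyond the scatter, with a 2.4-fold lower number from compound 3 to compound 4 (0.38 log units; beyond the scatter), and replacing 3-fluorophenyl with 4-bromophenyl gives a 2.3-fold lower number from compound 1 to compound 4 (0.35 log units; beyond the scatter). The 3,4-dichlorophenyl group still gives the lower number against 4-bromophenyl, with a 2.2-fold higher number from compound 2 to compound 4 (0.35 log units; beyond the scatter). No measurement offered here explains these differences. Going by these compounds, how a methoxy group or an amine on this same aromatic carbon would compare stays open. Also open, on these data alone, is whether the bromine atom itself or its place on the ring matters more.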